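Methoxy pattern on the aryl ring of the shared core

The source may hold more compounds than are shown below. What is called first, only, known or untested is meant among the compounds shown, and "the series" means these compounds.

Compound 1 `CCC1=C(O)c2c(oc(-c3cccc(C)c3)cc2=O)C(CC)(CC)C1=O` is the reference point: in a functional assay on KBVIN cells (Homo sapiens) for antiproliferative activity, read by sulforhodamine B assay, with a stated time of 3 days (on this read-out lower numbers stand for an effect already at smaller amounts and higher numbers for an effect only at larger amounts of compound), compound 1 gives 3.69 uM. Compound 2 `CCC1=C(O)c2c(oc(-c3ccc(OC)c(C)c3)cc2=O)C(CC)(CC)C1=O` differs from it by methoxy in place of hydrogen on an aromatic carbon; in this assay compound 2 gives 0.1 uM, which is a 37-fold lower number from compound 1 to compound 2 (1.57 log units; beyond the scatter). Compound 3 `CCC1=C(O)c2c(oc(-c3ccc(OC)c(OC)c3)cc2=O)C(CC)(CC)C1=O` carries two methoxy groups and in this assay compound 3 gives 1 uM, a step of a 10-fold higher number from compound 2 to compound 3 (1.00 log units; beyond the scatter). Within the three measured compounds, compound 2 stands apart, with both neighbours beyond the scatter. The difference between the core of compound 1 and the core of compound 3 is not broken down here.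

Compound 4 `CCC1=C(O)c2c(oc(-c3cc(OC)c(OC)c(OC)c3)cc2=O)C(CC)(CC)C1=O` remains to be measured. It differs from compound 3 by methoxy in place of hydrogen on an aromatic carbon. Among the measured compounds shown here, this is the same kind of change as the one from compound 1 to compound 2, not the same: there the entering group sits ortho to a methyl group and para to a large group, here it sits ortho to a methoxy group, meta to a large group and meta to a methoxy group. For the measured compounds named here, only one measured instance of this kind of change exists, namely a 37-fold lower number from compound 1 to compound 2 (1.57 log units; beyond the scatter), and its surround differs from the present one, so that step cannot simply be carried over. The expected step is therefore a 1.2-fold higher number from compound 3 to compound 4 (0.08 log units; within the scatter), well short of the earlier one. For compound 4 the estimate in this assay is 1.2 uM, expected to fall between 0.25 uM and 6 uM.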

Compound 4, concentration for half-maximal effect: 5.6 uM
Compound 4: middle estimate off by 4.7-fold (0.67 log units), on the low side; low and high end bracket the measured number.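

In this assay the entry of a methoxy group gives a 5.6-fold higher number from compound 3 to compound 4 (0.75 log units; beyond the scatter), so the change that lowers the number on the core of compound 1 raises it on the core of compound 3, and the two steps differ in direction as well as in size: the same change on two cores in this assay, a 37-fold lower number (1.57 log units; beyond the scatter) from compound 1 to compound 2 and a 5.6-fold higher number (0.75 log units; beyond the scatter) from compound 3 to compound 4, 210-fold (2.32 log units) apart, beyond the scatter of two such steps

For this series, methoxy in place of hydrogen on an aromatic carbon therefore cannot be carried from one core to another as a fixed step, and not even the direction of the step holds across these two pairs. What the pairs do not show is what sets the difference: in compound 4 the methoxy sits ortho to a methoxy group, meta to a large group and meta to a methoxy group, the earlier pair has a different surround, and two steps give a contrast rather than a rule for other members of the series.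

The aryl ring in the compounds shown carries only methyl and methoxy groups, so it remains open how a hydroxyl group, a chlorine atom or an amine would behave there. From the compounds shown here alone, whether a longer chain in place of the ethyl groups on the shared core would alter either step also remains open.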